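The compounds below may be only part of what the source reports. "The series", "measured", "known", "first", "only" and "open" are said of these compounds alone.

Of the compounds shown here, three with a shared core have been tested in a functional assay on A549 cells (Homo sapiens) for cytotoxicity, read by MTT assay, with a stated time of 24 h; a higher number here means a weaker inhibitor, a lower number a stronger inhibitor. Compound 1 `FC(F)(F)Oc1ccc(-c2cc(COc3ccccc3-c3nc4ccccc4s3)on2)cc1` gives 23900 nM. Compound 2 `Brc1ccc(-c2cc(COc3ccccc3-c3nc4ccccc4s3)on2)cc1` gives 19200 nM in this assay, and compound 3 `Clc1ccc(-c2cc(COc3ccccc3-c3nc4ccccc4s3)on2)cc1` gives 18800 nM. Compound 3 stands within the scatter of both others: the step of a 1.3-fold lower number from compound 1 to compound 3 (0.10 log units; within the scatter) and the step of a 1.0-fold lower number from compound 2 to compound 3 (0.01 log units; within the scatter) are each too small to count as a real difference, as is a 1.2-fold lower number from compound 1 to compound 2 (0.10 log units; within the scatter).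

Compound 4 `Cc1ccc(-c2cc(COc3ccccc3-c3nc4ccccc4s3)on2)cc1` is not yet measured. It differs from compound 3 by methyl in place of chloro on an aromatic carbon. All three measured steps swap one group for another at this same aromatic carbon, and none of them moved the number beyond the scatter, so a fourth swap of the same kind at the same place is expected to leave the number where the others lie, with no step in either direction that rises above the noise. The expected step is a 1.0-fold higher number from compound 3 to compound 4 (0.02 log units; within the scatter). Compound 4 is therefore estimated at 19500 nM in this assay, with a range from 9000 nM to 42000 nM.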

Compound 4, half-maximal inhibitory concentration: 16400 nM
Estimate against measurement, compound 4: 1.2-fold (0.08 log units) above; the measured number falls inside the stated range.
By their numbers in this assay, from the lowest: compounds 4, 3, 2 and 1 (each within the scatter of the next).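

In this assay methyl is the first group shown at this place, para to a large group, that joins the ring through carbon rather than through a halogen or oxygen. Its steps are a 1.1-fold lower number from compound 3 to compound 4 (0.06 log units; within the scatter) and a 1.2-fold lower number from compound 2 to compound 4 (0.07 log units; within the scatter), and even the widest gap among the four compounds, a 1.5-fold lower number from compound 1 to compound 4 (0.16 log units; within the scatter), does not separate them, so trifluoromethoxy, bromo, chloro and methyl cannot be told apart here. No measurement is available that explains this flat result.

On these data alone, it remains open whether an amine, a carboxylic acid or a longer chain such as butyl at this same carbon would shift the number beyond the scatter. All four compounds share one core, so they also say nothing about changes made elsewhere in the structure.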